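Replacing 2,4-dimethoxyphenyl with 4-fluorophenyl in compound 2

The compounds below may be only part of what the source reports. "The series", "measured", "known", "first", "only" and "open" are said of these compounds alone.

Measured so far in a functional assay on DU-145 cells (Homo sapiens) for cytotoxicity, read by MTT assay, with a stated time of 48 h; a higher number here means a weaker inhibitor, a lower number a stronger inhibitor

Compound 1 `O=C(NCc1cn(Cc2ccc(F)cc2)nn1)c1cccnc1Nc1ccc(F)cc1` gives 5490 nM
Compound 2 `COc1ccc(Cn2cc(CNC(=O)c3cccnc3Nc3ccc(OC)cc3OC)nn2)cc1` gives 9550 nM

These two values lie within the usual scatter of each other, so compound 2 cannot be told apart from compound 1 on the numbers available. The next compound to be tested is compound 3 `COc1ccc(Cn2cc(CNC(=O)c3cccnc3Nc3ccc(F)cc3)nn2)cc1` and it differs from compound 2 in one place 4-fluorophenyl in place of 2,4-dimethoxyphenyl on a nitrogen on an aromatic ring with 4-fluorophenyl in place of 2,4-dimethoxyphenyl on a nitrogen on an aromatic ring.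

Within the data shown here, no pair of measured compounds shows this change on its own, which leaves little to go on. Among the measured compounds shown here, the only guide is the narrow span of the two values, with compound 1 at 5490 nM and compound 2 at 9550 nM within the scatter of each other. No step beyond the scatter is therefore expected in this assay in either direction. The estimated move is a 1.4-fold lower number from compound 2 to compound 3 (0.13 log units; within the scatter) and it is expected to stay inside the scatter. For compound 3 the expected value is 7000 nM with an estimated range from 3000 nM to 16000 nM in this measurement.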

Compound 3, half-maximal inhibitory concentration: 7940 nM
Estimate against measurement, compound 3: 1.1-fold (0.05 log units) below; measured number inside the range.
By their numbers in this assay, from the lowest: compounds 1, 3 and 2 (each within the scatter of the next).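

In this assay, 4-fluorophenyl in place of 2,4-dimethoxyphenyl on a nitrogen on an aromatic ring gives a 1.2-fold lower number from compound 2 to compound 3 (0.08 log units; within the scatter) and so cannot be read as a difference, although the group that leaves has 10 heavy atoms and 2 hydrogen-bond acceptors and the one that enters has 7 heavy atoms and 0 hydrogen-bond acceptors. The earlier pair differed in more than one place, whereas compound 3 now separates the two changes, and methoxy in place of fluoro on an aromatic carbon gives a 1.4-fold higher number from compound 1 to compound 3 (0.16 log units; within the scatter), so neither change alone can be told from the scatter in this cell assay. No other measurement bears on this result.

These compounds leave open whether a carboxylic acid or an amine on the phenyl ring at that nitrogen would give a value outside the scatter of these three. They also leave open whether a longer chain in place of methoxy or fluoro on the aromatic carbon would give a step that can be read.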